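The source may report more compounds than this note shows. Statements on the series, on what has been measured and on what is new or still open speak of the compounds shown alone.

Compound 1 `C[C@H](NC(=S)Nc1cc(C(F)(F)F)cc(C(F)(F)F)c1)c1nc2ccccc2[nH]1` and compound 3 `CC(C)C[C@H](NC(=S)Nc1cc(C(F)(F)F)cc(C(F)(F)F)c1)c1nc2ccccc2[nH]1` share one core, while compound 2 `C[C@@H](NC(=S)NCc1ccccc1)c1nc2ccccc2[nH]1` and the as yet unmeasured compound 4 `CC(C)C[C@@H](NC(=S)NCc1ccccc1)c1nc2ccccc2[nH]1` share another; how the two cores differ is not broken down here. In a functional assay on A549 cells (Homo sapiens) for cytotoxicity, read by MTT assay (on this read-out higher numbers stand for weaker inhibition and lower numbers for stronger inhibition), compound 1 gives 220000 nM, compound 3 gives 17400 nM and compound 2 gives 18700 nM. The change isopropyl in place of hydrogen on a saturated chain carbon, two bonds along the chain from an amide-type nitrogen and an aromatic carbon made a 13-fold lower number from compound 1 to compound 3 (1.10 log units; beyond the scatter). The same change, (isopropyl in place of hydrogen on a saturated chain carbon, two bonds along the chain from an amide-type nitrogen and an aromatic carbon), separates compound 4 from compound 2, at the same place on the chain. Within the data shown here, the step expected from compound 2 to compound 4 in this assay is a 3.7-fold lower number from compound 2 to compound 4 (0.57 log units; beyond the scatter), taken as smaller than the earlier one because compound 2 already sits at 18700 nM, far under the number of compound 1, and only one instance of the change has been measured. Compound 4 is therefore estimated at 5000 nM, with an expected range from 1500 nM to 20000 nM.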

Compound 4, half-maximal inhibitory concentration: 22400 nM
Compound 4: the middle estimate sits 4.5-fold (0.65 log units) below what was measured; measured number above the stated range.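

In this assay, the isopropyl change does not carry over as a fixed step between the two cores: the same change on two cores in this assay, a 13-fold lower number (1.10 log units; beyond the scatter) from compound 1 to compound 3 and a 1.2-fold higher number (0.08 log units; within the scatter) from compound 2 to compound 4, 15-fold (1.18 log units) apart, beyond the scatter of two such steps. On the core of compound 2, the step is a 1.2-fold higher number from compound 2 to compound 4 (0.08 log units; within the scatter) and so gives no measurable shift, whereas the core of compound 1 responds strongly. Among these compounds, with only one pair on each core, this shows that the step depends on the core but not which difference between the cores is responsible, nor how any further core would respond.

On these data alone, it remains open whether an ethyl group or a longer chain in place of isopropyl would follow the pattern of either core. As far as these compounds go, the behaviour of an amine or a carboxylic acid at this chain carbon also remains open.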